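The source may report more compounds than this note shows. Statements on the series, on what has been measured and on what is new or still open speak of the compounds shown alone.

Values in a functional assay on NCI-H146 cells (Homo sapiens) for antiproliferative activity, read by WST assay, with a stated time of 4 days; a lower number here means a stronger inhibitor, a higher number a weaker inhibitor:
- Compound 1 `Cc1c(C(=O)NCCCN2CCN(C)CC2)c(-c2cccc(N3CCN(c4ccc(C(=O)NS(=O)(=O)c5ccc(N[C@H](CCN(C)C)CSc6ccccc6)c([N+](=O)[O-])c5)cc4)CC3)c2)c(-c2ccc(Cl)cc2)n1C`: > 10000 nM (a limit of the assay)
- Compound 2 `CCn1c(C)c(C(=O)O)c(-c2cccc(N3CCN(c4ccc(NS(=O)(=O)c5ccc(N[C@H](CCN(C)C)CSc6ccccc6)c([N+](=O)[O-])c5)cc4)CC3)c2)c1-c1ccc(Cl)cc1`: 8.1 nM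

Among the compounds with values here, compound 2 holds the only numerical value in the set, and no measured pair differs in a single place. Compound 3 `Cc1c(C(=O)O)c(-c2cccc(N3CCN(c4ccc(NS(=O)(=O)c5ccc(N[C@H](CCN(C)C)CSc6ccccc6)c([N+](=O)[O-])c5)cc4)CC3)c2)c(-c2ccc(Cl)cc2)n1C1CC1` carries cyclopropyl in place of ethyl on an aromatic nitrogen. Within the data shown here, with no measured step as a guide, no change beyond the scatter is expected in this assay, and the expected step is a 1.2-fold higher number from compound 2 to compound 3 (0.09 log units; within the scatter). The estimated value for compound 3 is 10 nM, with an expected range of 3 nM to 35 nM.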

Compound 3, half-maximal inhibitory concentration: 69 nM
For compound 3 the middle estimate is 6.9-fold (0.84 log units) below the measured one, outside the stated range (above it).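

In this assay, within the data shown here, the first step that changes one place only is cyclopropyl in place of ethyl on the aromatic nitrogen, which gives an 8.5-fold higher number from compound 2 to compound 3 (0.93 log units; beyond the scatter). This position is therefore not indifferent to its substituent: a small change to this group, with no change in net charge or in hydrogen-bond donors and acceptors, moves the number beyond the scatter. Nothing measured here accounts for the step.

From the compounds shown here alone, whether the ring or the extra carbon drives the step remains open, and propyl or isopropyl on this nitrogen would separate the two. Going by these compounds, whether the step carries over to other compounds also remains open.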